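Compound 3: methyl in place of dimethylcarbamoyl

The source may report more compounds than this note shows. Statements on the series, on what has been measured and on what is new or still open speak of the compounds shown alone.

Measured so far in a physicochemical assay for solubility; on this read-out lower numbers stand for lower solubility and higher numbers for higher solubility:
Compound 1 `CN(C)CC(=O)N1CCC[C@H]1C(=O)N1CCC(NS(=O)(=O)c2cc(S(=O)(=O)c3ccccc3)ccc2C(F)(F)F)CC1`: 100000 nM
Compound 2 `CN(C)C(=O)N1CCC[C@H]1C(=O)N1CCC(NS(=O)(=O)c2cc(S(=O)(=O)c3ccccc3)ccc2C(F)(F)F)CC1`: 100000 nM

On these numbers, compound 2 stands level with compound 1, and the two read the same at the digits given. The next structure, compound 3 `CN1CCC[C@H]1C(=O)N1CCC(NS(=O)(=O)c2cc(S(=O)(=O)c3ccccc3)ccc2C(F)(F)F)CC1`, carries methyl in place of dimethylcarbamoyl on an amine nitrogen in a ring. Among the compounds with values here, only one measured step bears on this change, and it is no change at the digits printed from compound 1 to compound 2 (within the scatter). That step swapped dimethylamino for (dimethylamino)methyl on a carbonyl carbon, which is a different edit, so it offers only a loose guide. With that single step as the evidence, no shift beyond the scatter is expected in this assay. The expected step is no change at the digits printed from compound 2 to compound 3 (within the scatter). For compound 3 the estimated value is 100000 nM, with an expected range from 50000 nM to 150000 nM.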

Compound 3, solubility: 100000 nM
Beside the measured number, compound 3's estimate shows no gap at the digits printed, within the range that was stated.
By their numbers in this assay, from the lowest: compounds 1, 2 and 3 (each within the scatter of the next).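

In this assay, the amine nitrogen in the ring now carries methyl in place of dimethylcarbamoyl, and the step reads no change at the digits printed from compound 2 to compound 3 (within the scatter). This goes further than the edit on the carbonyl carbon that separates the two earlier compounds: the carbonyl attached to this nitrogen leaves altogether, and even the swap of ((dimethylamino)methyl)carbonyl for methyl gives no change at the digits printed from compound 1 to compound 3 (within the scatter), so across the three groups shown on this nitrogen the read-out does not separate them. No measurement offered here accounts for this flat result.

From the compounds shown here alone, it remains open whether a hydrogen on this nitrogen, or a longer chain ending in a carboxylic acid, would read differently from these three compounds. All three also share the rest of the core, so the compounds shown say nothing about changes elsewhere, such as at the trifluoromethyl group.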